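Compound 3 against the cytotoxicity limit

This account rests on a few compounds, and the source may have more. Where it says the series, first, only, none or still open, it means among the compounds named here.

Measured so far:
Compound 1 `C/C(=N\OCC(=O)NCC(=O)O)c1ccc(NC(=O)c2cc(Br)ccc2O)cc1`: > 200000 nM
Compound 2 `C/C(=N\OCC(=O)N[C@H](C(=O)N[C@@H](CCCCN)C(=O)N1CCC[C@H]1C(=O)N1CCC[C@@H]1C(=O)N[C@H](CCCNC(=N)N)C(=O)O)[C@@H](C)O)c1ccc(NC(=O)c2cc(Br)ccc2O)cc1`: > 200000 nM

In a functional assay on MONO-MAC-6 cells (Homo sapiens) for cytotoxicity, read by MTT assay, with a stated time of 24 h (on this read-out lower numbers stand for stronger inhibition and higher numbers for weaker inhibition), compound 1 gives > 200000 nM, which is a limit and not a number. Compound 2 gives > 200000 nM, which is also a limit. Compound 1 therefore stands at the limit of > 200000 nM in this assay, at which 2 of the 2 values shown sit, and the series offers no numerical value to work from.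

Compound 3 `C/C(=N\OCC(=O)N[C@H](C(=O)O)[C@@H](C)O)c1ccc(NC(=O)c2cc(Br)ccc2O)cc1` has not yet been measured. It differs from compound 1 by 1-hydroxyethyl in place of hydrogen on a saturated chain carbon bound to an amide-type nitrogen and a carbonyl carbon. Read one bond further out, the same difference is carboxymethyl to 1-carboxy-2-hydroxypropyl.

Going by the values given here, no measured step gives a size for this change. No step beyond the usual scatter is expected in this assay, in either direction, and the expected a number no higher from compound 1 to compound 3 (the limit leaves the size open) is small. This expectation rests on compound 1 at > 200000 nM, which is a limit. Compound 3 is estimated at 200000 nM, with an expected range of 120000 nM to 400000 nM, and it will most likely be reported only as a limit.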

Compound 3, half-maximal inhibitory concentration: > 200000 nM
Compound 3: no number, only a limit; the forecaster's own chance of this, stated with the estimate: 90%; the middle value lies on the limit itself.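

Compound 1 and compound 3 both stand only as limits in this assay, so no step can be read between them: the limit of > 200000 nM in this assay, at which 3 of the 3 values shown sit.

Whether 1-hydroxyethyl in place of hydrogen changes cytotoxicity at all remains open, as does the concentration at which any of the compounds shown would give a number.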